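Notes on the N-arm change from compound 1

The source may report more compounds than this note shows. Statements on the series, on what has been measured and on what is new or still open speak of the compounds shown alone.

Compound 1 `Clc1cc(Cl)cc(CO[C@H]2CCCN(Cc3ccccn3)[C@H]2c2ccccc2)c1` is the parent of this step. In an assay on isolated protein for activation of cGMP-dependent protein kinase 1 (Homo sapiens), read by ADP-Glo, with stated times of 120 min and 40 min (on this read-out higher numbers stand for an effect only at larger amounts of compound and lower numbers for an effect already at smaller amounts), compound 1 gives only a limit, > 200000 nM. Compound 3 `Clc1cc(Cl)cc(CO[C@H]2CCCN(Cc3nccs3)[C@H]2c2ccccc2)c1` likewise gives only a limit in this assay, > 200000 nM. Because both sit at the limit of > 200000 nM in this assay, at which 2 of the 3 values shown sit, the step that the two limits leave unreadable from compound 1 to compound 3 cannot be read in size or direction. Going by the values given here, compound 2 `OC[C@@H](O[C@H]1CCCN(Cc2cccc3nonc23)[C@H]1c1ccccc1)c1cc(Cl)cc(Cl)c1` gives 8000 nM in this assay, but it differs from compound 1 in more than one place, so no single step connects the two. Compound 4 `COc1ccc(C(=O)O)cc1CN1CCC[C@H](OCc2cc(Cl)cc(Cl)c2)[C@@H]1c1ccccc1` carries the change (5-carboxy-2-methoxyphenyl in place of pyridin-2-yl on a saturated chain carbon bound to an amine nitrogen in a ring). No readable measured step bears on this change, and compound 1 supplies only a limit as a starting point, so the step of an at least 2.0-fold lower number from compound 1 to compound 4 (0.30 log units; that floor lies within the scatter) is expected only loosely. Compound 4 is estimated at 100000 nM, within a range of 10000 nM to 300000 nM.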

Compound 4, half-maximal effective concentration: 123000 nM
Compound 4: middle estimate off by 1.2-fold (0.09 log units), on the low side; the measured number falls inside the stated range.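

At this place, on a saturated chain carbon bound to an amine nitrogen in a ring, 5-carboxy-2-methoxyphenyl gives compound 4 a readable number in this assay, whereas the arms of compound 1 and compound 3 stop at a limit: the limit of > 200000 nM in this assay, at which 2 of the 4 values shown sit.

The change reads as an at least 1.6-fold lower number from compound 1 to compound 4 (0.21 log units; that floor lies within the scatter), and also as an at least 1.6-fold lower number from compound 3 to compound 4 (0.21 log units; that floor lies within the scatter). Going by these compounds, both steps are floors, so the true size of the change remains unknown.

Which part of the 5-carboxy-2-methoxyphenyl arm matters stays open. Arms carrying the carboxylic acid alone, the methoxy alone, or a primary amide in place of the carboxylic acid would separate these contributions.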